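Sulfonylcarbamoyl in Place of Amide on a Shared Core

The compounds below may be only part of what the source reports. "The series", "measured", "known", "first", "only" and "open" are said of these compounds alone.

Of the compounds shown here, three on a shared core have been measured in an assay on microsomes from brain for inhibition of Fatty-acid amide hydrolase 1 (Rattus norvegicus), read by fluorescence and HPLC, with a stated time of 45 min; on this read-out lower numbers stand for stronger inhibition and higher numbers for weaker inhibition. Compound 1 `CC(=O)Nc1ccc2c(cnn2CC(=O)COc2ccc(Oc3ccccc3)cc2)c1` gives 3900 nM, compound 2 `COCC(=O)Nc1ccc2c(cnn2CC(=O)COc2ccc(Oc3ccccc3)cc2)c1` gives 6300 nM, and compound 3 `O=C(COc1ccc(Oc2ccccc2)cc1)Cn1ncc2cc(NC(=O)Nc3ccccc3)ccc21` gives 6000 nM. Compound 2 carries the highest of the three numbers, yet its separation from the others is slight: a 1.1-fold lower number from compound 2 to compound 3 (0.02 log units; within the scatter), and a 1.6-fold higher number from compound 1 to compound 2 (0.21 log units; within the scatter). All three numbers sit within the scatter of one another, so none of the compounds can be called stronger or weaker than the rest.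

Compound 4 `O=C(COc1ccc(Oc2ccccc2)cc1)Cn1ncc2cc(C(=O)NS(=O)(=O)C(F)(F)F)ccc21` has not yet been measured. It differs from compound 2 in one place: ((trifluoromethyl)sulfonyl)carbamoyl in place of ((methoxymethyl)carbonyl)amino on an aromatic carbon. Among the compounds with values here, no measured step involves a change of this kind. The two steps that touch the same aromatic carbon, a 1.6-fold higher number from compound 1 to compound 2 (0.21 log units; within the scatter) and a 1.5-fold higher number from compound 1 to compound 3 (0.19 log units; within the scatter), exchange only what hangs on the carbonyl of the amide, and both stayed within the scatter. The measured compounds show this position accepting varied groups, but offer no direct guide to a sulfonylcarbamoyl. Compound 4 is expected to stay close to the numbers already seen, with a 1.3-fold lower number from compound 2 to compound 4 (0.10 log units; within the scatter). The number of compound 4 in this assay is estimated at 5000 nM, within a range from 1500 nM to 20000 nM.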

Compound 4, half-maximal inhibitory concentration: 510 nM
Beside the measured number, compound 4's estimate is 9.8-fold (0.99 log units) above it; the whole stated range lies above it.
By their numbers in this assay, from the lowest: compound 4; then compounds 1, 3 and 2 (each within the scatter of the next).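

In this assay, this aromatic carbon proves far from indifferent to what it carries: ((trifluoromethyl)sulfonyl)carbamoyl in place of the earlier nitrogen-linked groups gives a 12-fold lower number from compound 2 to compound 4 (1.09 log units; beyond the scatter), a 12-fold lower number from compound 3 to compound 4 (1.07 log units; beyond the scatter) and a 7.6-fold lower number from compound 1 to compound 4 (0.88 log units; beyond the scatter), all beyond the scatter. The earlier exchanges, which altered only what hangs on the amide carbonyl, had left the compounds within the scatter of one another, so this is the first change shown at this position that separates one compound from the others. Nothing given here bears on why the number falls.

The change alters several things at once, replacing an attachment through nitrogen with one through a carbonyl carbon and adding a sulfonyl group and a trifluoromethyl group, and the compounds shown do not tell which of these parts carries the step. Going by these compounds, a carboxylic acid, a primary carboxamide or a (methylsulfonyl)carbamoyl group on the same aromatic carbon would begin to separate them, and whether the exchange gives a step of like size on any other core also remains open.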